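Moving a methyl on the thiophene ring of compound 3

The compounds below may be only part of what the source reports. "The series", "measured", "known", "first", "only" and "open" are said of these compounds alone.

Of the compounds shown here, three sharing one saturated bicyclic core have been tested in an ADME assay on MDCK cells (Canis lupus familiaris) for cytotoxicity, read by microscopy, with a stated time of 48 h; on this read-out lower numbers stand for higher toxicity in this test and higher numbers for lower toxicity in this test. Compound 1 `C[C@H]1[C@H](NCc2ccc(Cl)s2)C[C@H]2C[C@@H]1C2(C)C` gives 25000 nM. Compound 2 `C[C@H]1[C@H](NCc2sccc2-c2ccccc2)C[C@H]2C[C@@H]1C2(C)C` gives 12500 nM. Compound 3 `Cc1csc(CN[C@@H]2C[C@H]3C[C@@H]([C@H]2C)C3(C)C)c1` gives 12500 nM; it stands level with compound 2 at the digits shown, and together they are the lowest of the three numbers, while compound 1 is the furthest from it, though the step of a 2.0-fold lower number from compound 1 to compound 3 (0.30 log units; within the scatter) lies within the scatter. For the measured compounds named here, the only measured step that changes the group on the saturated chain carbon bound to the amine nitrogen is this one, and it stayed within the scatter.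

Compound 4 `Cc1ccsc1CN[C@@H]1C[C@H]2C[C@@H]([C@H]1C)C2(C)C` has not been measured in this assay. It differs from compound 3 in one place: 3-methylthiophen-2-yl in place of 4-methylthiophen-2-yl on a saturated chain carbon bound to an amine nitrogen. Going by the values given here, no measured step moves a methyl from one position on the thiophene ring to another, so the expectation rests on the one step that did change this group and stayed within the scatter. The step from compound 3 to compound 4 is therefore expected to be no change at the digits printed from compound 3 to compound 4 (within the scatter), with no change beyond the scatter in either direction. Compound 4 is estimated at 12500 nM, within a range from 6250 nM to 25000 nM.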

Compound 4, minimum cytotoxic concentration: 10000 nM
Beside the measured number, compound 4's estimate is 1.3-fold (0.10 log units) above it; measured number inside the range.
By their numbers in this assay, from the lowest: compounds 4, 2, 3 and 1 (each within the scatter of the next, the first and the last beyond it).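

Moving the methyl on the thiophene ring, with 3-methylthiophen-2-yl in place of 4-methylthiophen-2-yl, gives in this assay a 1.3-fold lower number from compound 3 to compound 4 (0.10 log units; within the scatter) and so shows that this shift of one methyl leaves the reading within the scatter. Methyl in place of phenyl on an aromatic carbon gives a 1.3-fold lower number from compound 2 to compound 4 (0.10 log units; within the scatter) and likewise does not separate the two compounds. For the compounds shown here, only 3-methylthiophen-2-yl in place of 5-chlorothiophen-2-yl gives a step past the scatter, a 2.5-fold lower number from compound 1 to compound 4 (0.40 log units; beyond the scatter) and this is the one such step among the four compounds, still a modest one.

Nothing measured here offers an explanation for these numbers. As far as these compounds go, whether an amine or a carboxylic acid on the thiophene ring in place of the methyl would carry the number beyond the scatter stays open.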